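The source may report more compounds than this note shows. Statements on the series, on what has been measured and on what is new or still open speak of the compounds shown alone.

Of the compounds shown here, three with a shared core have been tested in a functional assay on U2OS cells (Homo sapiens) for antiproliferative activity, read by MTT assay, with a stated time of 72 h; a higher number here means a weaker inhibitor, a lower number a stronger inhibitor. Compound 1 `Nc1ccc(SCC(=O)Nc2ccc3nc(NC(=O)c4ccc(C(F)(F)F)cc4)sc3c2)cc1` gives 1220 nM, compound 2 `O=C(CSc1cccc(O)c1)Nc1ccc2nc(NC(=O)c3cc(Cl)cc(Cl)c3)sc2c1` gives 1530 nM, and compound 3 `O=C(CSc1nc2ccccc2[nH]1)Nc1ccc2nc(NC(=O)c3ccc(C(F)(F)F)cc3)sc2c1` gives 7110 nM. Compound 2 therefore stands second highest of the three numbers, within the scatter of compound 1 and well apart from compound 3. Going by the values given here, the only change measured in a single place is a 5.8-fold higher number from compound 1 to compound 3 (0.77 log units; beyond the scatter), and it concerns the group on the sulfur. Compound 4 `O=C(CSc1cccc(O)c1)Nc1ccc2nc(NC(=O)c3ccccc3)sc2c1` alters a different part of the molecule: phenyl in place of 3,5-dichlorophenyl on a carbonyl carbon. Among the compounds with values here, no measured step touches this position, so the data offer no direct guide; compounds 1 and 2 differ here too, but they also differ on the sulfur. The expected step is a 1.5-fold higher number from compound 2 to compound 4 (0.18 log units; within the scatter), small and possibly within the scatter. Compound 4 is thus estimated at 2300 nM, in the range 900 nM to 6000 nM.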

Compound 4, half-maximal inhibitory concentration: > 100000 nM
Compound 4 gave a limit, no number; the forecaster's own chance of this, stated with the estimate: 5%; middle value at least 43-fold (1.63 log units) from the limit.
By their numbers in this assay, from the lowest: compounds 1 and 2 (each within the scatter of the next); then compound 3. At a limit, above all of these: compound 4.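

In this assay, the group on this carbonyl carbon matters greatly: phenyl in place of 3,5-dichlorophenyl gives an at least 65-fold higher number from compound 2 to compound 4 (1.81 log units; beyond the scatter). The value of compound 4 is a limit and not a number, so the true size of this step stays unknown: the limit of > 100000 nM in this assay, at which 1 of the 4 values shown sits.
Before this, the only step measured in one place concerned the group on the sulfur, so this position had no measured step.

Still open, going by these compounds, is whether a single chlorine on the phenyl ring would be enough. Also open, on these data alone, is how fluorine or a methoxy group would fare in place of the two chlorines.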